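A Chloro Step on a Weakly Antiproliferative Compound

A few compounds are considered here, and "the series" means these few. Any claim that something is new, unique, unknown or untested is made for them only; others in the source may bear on it.

Going by the values given here, in a functional assay on MCF7 cells (Homo sapiens) for antiproliferative activity, read by MTT assay, with a stated time of 48 h (a higher number here means a weaker inhibitor, a lower number a stronger inhibitor), compound 1 (`Oc1ccc2ccccc2c1C(Nc1nc2ccccc2s1)c1cn(-c2ccccc2)nc1-c1ccccc1`) gives 48900 nM and holds the higher of the two numbers measured so far, which makes it the weaker inhibitor of the pair. Among the compounds with values here, the only comparison is compound 2 (`COc1cccc(-c2nn(-c3ccccc3)cc2C(Nc2nc3ccccc3s2)c2c(O)ccc3ccccc23)c1`), which gives 16900 nM in the same measurement. Compound 3 (`Oc1ccc2ccccc2c1C(Nc1nc2ccc(Cl)cc2s1)c1cn(-c2ccccc2)nc1-c1ccccc1`) departs from compound 1 by a single change, chloro in place of hydrogen on an aromatic carbon, which turns 1,3-benzothiazol-2-yl into 6-chloro-1,3-benzothiazol-2-yl. Within the data shown here, one measured step bears on this, and only loosely: compound 2 shows a 2.9-fold lower number from compound 1 to compound 2 (0.46 log units; beyond the scatter) for methoxy in place of hydrogen on an aromatic carbon, a different group at a different place from the chloro. Among the measured compounds shown here, no chloro step has been measured, so a modest shift toward a lower number is expected, with real uncertainty about its size and even its direction. The estimated change is a 1.7-fold lower number from compound 1 to compound 3 (0.24 log units; within the scatter) in this series. Compound 3 is therefore expected to read 28000 nM with an estimated range of 9000 nM to 70000 nM in this measurement.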

Compound 3, half-maximal inhibitory concentration: 36300 nM
Beside the measured number, compound 3's estimate is 1.3-fold (0.11 log units) below it; measured number inside the range.
By their numbers in this assay, from the lowest: compound 2; then compounds 3 and 1 (each within the scatter of the next).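

Compounds 1 and 2 share the 1,3-benzothiazol-2-yl group and so could say nothing about it; compound 3 opens that part of the molecule to comparison. In this assay, 6-chloro-1,3-benzothiazol-2-yl in place of 1,3-benzothiazol-2-yl gives a 1.3-fold lower number from compound 1 to compound 3 (0.13 log units; within the scatter), so this aromatic carbon accepts a chloro with no reading that can be told apart from that of hydrogen, while the methoxy change elsewhere in the molecule gives a 2.9-fold lower number from compound 1 to compound 2 (0.46 log units; beyond the scatter), which stays the only step shown that lies beyond the scatter. No measurement offered here explains why the chloro step is so small.

From the compounds shown here alone, one chloro cannot speak for the whole position, so it remains open whether an amine, a carboxylic acid or a methoxy on this same aromatic carbon would read any differently in this assay. Going by these compounds, it is equally open whether the chloro of compound 3 and the methoxy of compound 2, carried together on the core of compound 1, would give a reading different from that of the methoxy alone.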